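The compounds below may be only part of what the source reports. "The series", "measured", "known", "first", "only" and "open" are said of these compounds alone.

Measured compounds:
- compound 1, `CC(C)(C)OC(=O)N1C[C@@H](n2cc(-c3ccc(N)nc3)nn2)C[C@H]1C(=O)Nc1ccc(Cl)c(C(F)(F)F)c1`: 48.6%
- compound 2, `CC(C)(C)C(=O)Nc1ccc(-c2cn([C@@H]3CN[C@H](C(=O)Nc4ccc(Cl)c(C(F)(F)F)c4)C3)nn2)cn1`: 19.1%
- compound 3, `CC(C)(C)OC(=O)N1C[C@@H](n2cc(-c3ccc4c(N)n[nH]c4c3)nn2)C[C@H]1C(=O)Nc1ccc(Cl)c(C(F)(F)F)c1`: 37.1%

In a functional assay on K562/Adr cells (Homo sapiens) for inhibition, read by MTT assay, with a stated time of 48 h, tested at 30 uM (on this read-out lower numbers stand for less inhibition and higher numbers for more inhibition at the one concentration tested (going by the name of the read-out)), compound 3 stands second highest of the three numbers: compound 1 sits above it, and the gap is a number 11.5 percentage points lower from compound 1 to compound 3 (beyond the scatter), beyond the scatter; compound 2 sits furthest below it, also beyond the scatter. Within the data shown here, the one measured step, from compound 1 to compound 3, concerns the group on the aromatic carbon of the core and says nothing about the amide side of the molecule. Compound 2 differs from compound 3 in two places at once, so its number is only a point of reference.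

Compound 4, `CC(C)(C)OC(=O)N1C[C@@H](n2cc(-c3ccc4c(N)n[nH]c4c3)nn2)C[C@H]1C(=O)Nc1ccc(Br)cc1`, keeps the core of compound 3 and changes the amide side: 4-bromophenyl in place of 4-chloro-3-(trifluoromethyl)phenyl on an amide-type nitrogen. Among the measured compounds shown here, no measured step touches this position, so no step bears on it directly; the size and direction of the change in this assay cannot be read from the series. Treated as an unsupported change at the amide, compound 4 is expected to give 30%, within 8% to 52%, which means an estimated step of a number 7.1 percentage points lower from compound 3 to compound 4 (within the scatter), most likely not beyond the scatter.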

Compound 4, a percentage reported as inhibition, at one concentration (the size of the read-out at that concentration, not a potency): 23%
Compound 4: middle estimate off by 7 percentage points, on the high side, within the range that was stated.
By their numbers in this assay, from the lowest: compounds 2 and 4 (each within the scatter of the next); then compound 3; then compound 1.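

In this assay the amide side now has its first reading: 4-bromophenyl in place of 4-chloro-3-(trifluoromethyl)phenyl on the amide-type nitrogen gives a number 14.1 percentage points lower from compound 3 to compound 4 (beyond the scatter) and shows that the number responds to this position, not only to the group on the aromatic carbon. Alongside a number 11.5 percentage points lower from compound 1 to compound 3 (beyond the scatter) the series now holds single changes at two places, and both lower the number, so no single change shown so far raises it. Nothing available explains the size or direction of the step at the amide.

Because this change alters the halogen and also removes the trifluoromethyl group, the compounds shown do not separate the two, and a 4-chlorophenyl or a 3-(trifluoromethyl)phenyl amide would do so. Going by these compounds, whether the step carries over to the 6-aminopyridin-3-yl series of compound 1 also stays open.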